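Chlorine to amine on the shared core: cytotoxicity notes

The source may hold more compounds than are shown below. What is called first, only, known or untested is meant among the compounds shown, and "the series" means these compounds.

Measured so far in an ADME assay on L1210/0 cells (Mus musculus) for cytotoxicity, with a stated time of 48 h; a lower number here means a stronger inhibitor, a higher number a weaker inhibitor:
compound 1, `CC1(C)[C@@H](CO)CC[C@@]1(C)Cn1cnc2c(Cl)ncnc21`: 42800 nM
compound 2, `Nc1nc(N)c2ncn([C@H]3CCCC[C@H]3CO)c2n1`: a limit of this assay, > 200000 nM
compound 3, `Nc1nc(Cl)c2ncn([C@H]3CCCC[C@H]3CO)c2n1`: a limit of this assay, > 200000 nM

Within the data shown here, compound 1 holds the only number; the other two values are limits, a point marked by the limit of > 200000 nM in this assay, at which 2 of the 3 values shown sit. The step that the two limits leave unreadable from compound 3 to compound 2 is made by amino in place of chloro on an aromatic carbon. The difference between the core of compound 1 and the core of compound 3 is not broken down here.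

Compound 4, `CC1(C)[C@@H](CO)CC[C@@]1(C)Cn1cnc2c(N)ncnc21`, is not yet measured. It arises from compound 1 by amino in place of chloro on an aromatic carbon, the same kind of change as from compound 3 to compound 2, though there the place is also meta to an amino group (1 heavy atom). The step of a 1.9-fold higher number from compound 1 to compound 4 (0.27 log units; within the scatter) is only an expectation, resting on compound 1 at 42800 nM and on the unreadable step that the two limits leave unreadable from compound 3 to compound 2. Compound 4 is estimated at 80000 nM, between 20000 nM and 300000 nM.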

Compound 4, half-maximal inhibitory concentration: > 200000 nM
Compound 4: only a limit was reported; the forecaster's own chance of this, stated with the estimate: 30%; middle value at least 2.5-fold (0.39 log units) away from the limit.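

In this assay amino in place of chloro on an aromatic carbon gives an at least 4.6-fold higher number from compound 1 to compound 4 (0.66 log units; beyond the scatter) and so marks a clear rise on this core. Compound 4 gives > 200000 nM as a limit and not a number, so the full size of the step stays open: the limit of > 200000 nM in this assay, at which 3 of the 4 values shown sit.

The same change from compound 3 to compound 2 cannot be read, so nothing here shows that the step carries from one core to the other with the same direction or size.

Still open, on these data alone, is whether a group other than amino, such as methoxy or methylamino, at the same place on the core of compound 1 would keep a measurable number. Also open, as far as these compounds go, is how far the step reaches beyond the limit.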